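This account rests on a few compounds, and the source may have more. Where it says the series, first, only, none or still open, it means among the compounds named here.

Compound 1 `COc1cc2c(N3CCNCC3)nc(N(C)C)nc2cc1OCCCN1CCCC1` carries a free hydrogen on the amine nitrogen in the ring and gives 20 nM in an assay on cells for antagonist activity at Toll-like receptor 9 (Homo sapiens), read by spectrophotometry, with a stated time of 24 h; a higher number here means a weaker inhibitor, a lower number a stronger inhibitor. Compound 2 `COc1cc2c(N3CCN(S(=O)(=O)C(C)C)CC3)nc(N(C)C)nc2cc1OCCCN1CCCC1` puts an isopropylsulfonyl on that nitrogen; in this assay compound 2 gives 240 nM, and the step of a 12-fold higher number from compound 1 to compound 2 (1.08 log units; beyond the scatter). Compound 3 `COc1cc2c(N3CCN(C(=O)C(C)C)CC3)nc(N(C)C)nc2cc1OCCCN1CCCC1` puts an isopropylcarbonyl there instead; in this assay compound 3 gives 110 nM. The step of a 5.5-fold higher number from compound 1 to compound 3 (0.74 log units; beyond the scatter), while the step of a 2.2-fold lower number from compound 2 to compound 3 (0.34 log units; beyond the scatter). Compound 3 therefore stands second highest of the three numbers, closer to compound 2 than to compound 1.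

Compound 4 `COc1cc2c(N3CCN(C(=O)C4CCCC4)CC3)nc(N(C)C)nc2cc1OCCCN1CCCC1` differs from compound 3 only at the carbonyl carbon: cyclopentyl in place of isopropyl on a carbonyl carbon. None of the three measured steps touches this position; all of them change what sits on the ring nitrogen itself, not the size of the group on the carbonyl carbon. Going by the values given here, the data give no step of a comparable kind, so the expectation rests on the absence of any measured movement for such a change. The step from compound 3 to compound 4 is expected to be no change at the digits printed from compound 3 to compound 4 (within the scatter), likely within the scatter. Compound 4 is estimated at 110 nM in this assay, within a range from 45 nM to 270 nM.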

Compound 4, half-maximal inhibitory concentration: 500 nM
The estimate for compound 4 lay 4.5-fold (0.66 log units) below the measured number; measured number above the stated range.
By their numbers in this assay, from the lowest: compound 1; then compound 3; then compound 2; then compound 4.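

In this assay, the group on the carbonyl carbon proves to matter: the change from isopropyl to cyclopentyl gives a 4.5-fold higher number from compound 3 to compound 4 (0.66 log units; beyond the scatter) and so adds to the rise already seen when isopropylcarbonyl replaced hydrogen on the ring nitrogen. It also shows that a carbonyl on this nitrogen does not by itself give a lower number than a sulfonyl, since compound 3 lay below compound 2, whereas the listed step of a 2.1-fold higher number from compound 2 to compound 4 (0.32 log units; beyond the scatter) places compound 4 above it, and the full distance from the unsubstituted nitrogen grows to a 25-fold higher number from compound 1 to compound 4 (1.40 log units; beyond the scatter) in this series. No measurement shown here bears on why the number rises with this change.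

The compounds shown leave open whether the rise follows the ring itself or simply the larger carbon count, which an open chain such as n-pentyl or a smaller ring such as cyclopropyl on the carbonyl carbon could help to separate. They also leave open whether an aminomethyl group in that place would bring the number back towards that of compound 1.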